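A 6-fluoropyridin-3-yl swap on compound 1

This account rests on a few compounds, and the source may have more. Where it says the series, first, only, none or still open, it means among the compounds named here.

In an ADME assay on the whole organism (Mus musculus, strain BALB/c) for pharmacokinetics, read by LC-MS, with a stated time of 24 h, at a dose of 1 mg/kg by the intravenous route (on this read-out higher numbers stand for higher exposure at the dose given and lower numbers for lower exposure), compound 1 `Cn1nccc1-c1cc(C(F)(F)F)ccc1[C@H]1CCOc2cc(S(=O)(=O)Nc3nccs3)ccc21` gives 1300 nM. Two relatives were measured alongside it: compound 2 `Cn1nccc1-c1cc(C(F)(F)F)ccc1[C@H]1CCOc2cc(S(=O)(=O)Nc3ncccn3)ccc21` gives 2000 nM and compound 3 `Cn1nccc1-c1cc(C(F)(F)F)ccc1[C@H]1CCc2cc(S(=O)(=O)Nc3ncccn3)ccc21` gives 2000 nM. Compound 1 therefore stands within the scatter of both, and the three numbers do not separate it from either.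

Compound 4 `O=S(=O)(Nc1nccs1)c1ccc2c(c1)OCC[C@@H]2c1ccc(C(F)(F)F)cc1-c1ccc(F)nc1` keeps the core of compound 1 and its 1,3-thiazol-2-yl on the sulfonamide nitrogen, and it changes one group: 6-fluoropyridin-3-yl in place of 1-methyl-1H-pyrazol-5-yl on an aromatic carbon. The new ring sits on the same aromatic carbon that carried the 1-methyl-1H-pyrazol-5-yl.

For the measured compounds named here, only one measured step changes a single place, a 1.5-fold higher number from compound 1 to compound 2 (0.19 log units; within the scatter), and it lies at the sulfonamide nitrogen, not at this carbon. Going by the values given here, all three measured compounds carry the 1-methyl-1H-pyrazol-5-yl, so the data hold no direct precedent for this swap. The small size of the step to compound 2 offers only weak guidance, and no direction can be drawn from it. No shift beyond the scatter is therefore expected in this assay, though the range is kept wide. The estimated step is no change at the digits printed from compound 1 to compound 4 (within the scatter). Compound 4 is expected at 1300 nM, with an estimated range from 600 nM to 2800 nM.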

Compound 4, maximal plasma concentration: 800 nM
The estimate for compound 4 lay 1.6-fold (0.21 log units) above the measured number; measured number inside the range.
By their numbers in this assay, from the lowest: compounds 4, 1, 2 and 3 (each within the scatter of the next, the first and the last beyond it).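

In this assay, for the compounds shown here, the swap gives a 1.6-fold lower number from compound 1 to compound 4 (0.21 log units; within the scatter), the first reading at this aromatic carbon, as all the earlier compounds carry the 1-methyl-1H-pyrazol-5-yl. Going by these compounds alone, on this read-out, a five-membered aromatic ring with 2 hetero atoms gives way to 6-fluoropyridin-3-yl, a six-membered aromatic ring with 1 hetero atom, without a step that can be told from the scatter, and the same holds for the one earlier step at the sulfonamide nitrogen, a 1.5-fold higher number from compound 1 to compound 2 (0.19 log units; within the scatter). No measurement is available that would account for the number at this position.

This single swap does not tell whether the carbon would stay as undemanding with a quite different group, such as an amine or a carboxylic acid, in place of the aromatic ring. It also leaves open whether the swap would read the same with pyrimidin-2-yl on the sulfonamide nitrogen, as 6-fluoropyridin-3-yl appears here only together with 1,3-thiazol-2-yl.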